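Sulfonylurea series: pentyl for tert-butyl on a second core

The compounds below may be only part of what the source reports. "The series", "measured", "known", "first", "only" and "open" are said of these compounds alone.

Compound 1 `Cc1ccccc1Oc1ccc(C#N)cc1S(=O)(=O)NC(=O)NC(C)(C)C` gives 1470 nM in a functional assay on HEK293 cells for antagonist activity at thromboxane A2 receptor (Homo sapiens), read by fluorescence and calcium flux; on this read-out lower numbers stand for stronger inhibition and higher numbers for weaker inhibition. Compound 2 `CCCCCNC(=O)NS(=O)(=O)c1cc(C#N)ccc1Oc1ccccc1C` carries the change (pentyl in place of tert-butyl on an amide-type nitrogen), and in this assay compound 2 gives 1780 nM; the step is a 1.2-fold higher number from compound 1 to compound 2 (0.08 log units; within the scatter). Compound 3 `CC(C)(C)NC(=O)NS(=O)(=O)c1cc(C#N)ccc1Oc1ccc(F)cc1` differs from compound 1 in its core by 4-fluorophenyl in place of 2-methylphenyl on an oxygen on an aromatic ring; in this assay compound 3 gives 3890 nM, the step being a 2.6-fold higher number from compound 1 to compound 3 (0.42 log units; beyond the scatter), which leaves compound 3 with the highest number of the three measured. Compound 4 `CCCCCNC(=O)NS(=O)(=O)c1cc(C#N)ccc1Oc1ccc(F)cc1` is not yet measured; it repeats on the core of compound 3 the change (pentyl in place of tert-butyl on an amide-type nitrogen), the same change as between compound 1 and compound 2, at the same place. The step from compound 3 to compound 4 is expected to be a 1.2-fold higher number from compound 3 to compound 4 (0.07 log units; within the scatter), resting on the step of a 1.2-fold higher number from compound 1 to compound 2 (0.08 log units; within the scatter) made by this change on the core of compound 1. Compound 4 is estimated at 4600 nM, within a range of 2000 nM to 10500 nM.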

Compound 4, half-maximal inhibitory concentration: 9530 nM
Estimate against measurement, compound 4: 2.1-fold (0.32 log units) below, within the range that was stated.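

In this assay, pentyl in place of tert-butyl on the core of compound 3 gives a 2.4-fold higher number from compound 3 to compound 4 (0.39 log units; beyond the scatter), and beside the earlier step the gap cannot be told from scatter: the same change on two cores in this assay, a 1.2-fold higher number (0.08 log units; within the scatter) from compound 1 to compound 2 and a 2.4-fold higher number (0.39 log units; beyond the scatter) from compound 3 to compound 4, 2.0-fold (0.31 log units) apart, within the scatter of two such steps. Likewise, 4-fluorophenyl in place of 2-methylphenyl, read on the pentyl compounds, gives a 5.4-fold higher number from compound 2 to compound 4 (0.73 log units; beyond the scatter), in the same direction as on the tert-butyl compounds: the same change on two cores in this assay, a 2.6-fold higher number (0.42 log units; beyond the scatter) from compound 1 to compound 3 and a 5.4-fold higher number (0.73 log units; beyond the scatter) from compound 2 to compound 4, 2.0-fold (0.31 log units) apart, within the scatter of two such steps. Both changes therefore carry across these cores as far as the scatter can tell, but this does not show that the pentyl step truly differs in size between cores, nor that it holds on any further core.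

Open, as far as these compounds go, is whether a propyl group, a cyclohexyl group or a longer chain on the amide-type nitrogen follows pentyl. Also open, from the compounds shown here alone, is whether a 4-chlorophenyl group on the oxygen follows 4-fluorophenyl.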